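This account rests on a few compounds, and the source may have more. Where it says the series, first, only, none or still open, it means among the compounds named here.

Notes on the series. In an ADME assay on MRC5 cells (Homo sapiens) for cytotoxicity, read by MTT assay, with a stated time of 72 h (a lower number here means a stronger inhibitor, a higher number a weaker inhibitor), compound 1 (`O=C(Nc1nnc(-c2cccc(O)c2O)s1)c1ccccc1`) gives 23200 nM. Compound 2 (`O=C(Nc1nnc(-c2ccc(O)c(O)c2)s1)C1CCCCC1`) gives 24000 nM, which lies within the scatter of the value for compound 1, so the two stand level on the numbers available. Within the data shown here, these two compounds differ in more than one place, and no single-change step has been measured to size the next move.

Compound 3 (`CC(=O)Nc1nnc(-c2ccc(O)c(O)c2)s1`) differs from compound 2 by one change, methyl in place of cyclohexyl on a carbonyl carbon. The rest of compound 2 stays untouched. Among the measured compounds shown here, with no measured step for this change, the expectation in this assay is a small shift toward a higher number, not far beyond the scatter. For the measured compounds named here, the only guide is that compound 1 and compound 2 carry different groups on the carbonyl carbon and still stand level, with compound 2 at 24000 nM. The expected step of a 1.5-fold higher number from compound 2 to compound 3 (0.16 log units; within the scatter) is therefore modest. For compound 3 the estimated value is 35000 nM, with an expected range of 14000 nM to 90000 nM.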

Compound 3, half-maximal inhibitory concentration: 58600 nM
Compound 3: the middle estimate sits 1.7-fold (0.22 log units) below what was measured, and the stated range covers the measured number.
By their numbers in this assay, from the lowest: compounds 1 and 2 (each within the scatter of the next); then compound 3.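

Notes on the series, continued. In this assay, replacing cyclohexyl with methyl on a carbonyl carbon whose other neighbour is an amide-type nitrogen gives a 2.4-fold higher number from compound 2 to compound 3 (0.39 log units; beyond the scatter). Among these compounds, this is the first single-change step available, and it shows that the group at this position can move the number beyond the scatter, something the earlier pair could not show because those compounds differ in more than one place. Among the compounds shown here, the single step points toward weaker inhibition when cyclohexyl gives way to methyl, but nothing at hand accounts for this shift.

As far as these compounds go, with only cyclohexyl and methyl compared directly at this position, it remains open whether the number follows the carbon count of the group in a regular way or whether the ring itself matters, and a longer straight chain, a cyclopentyl ring or a carboxylic acid on the same carbonyl carbon would help separate these readings. From the compounds shown here alone, it also remains open whether the same change would give a step of similar size on the core of compound 1.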